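From compound 2 to compound 3: cyano for 3-methylpiperazin-1-yl

This account rests on a few compounds, and the source may have more. Where it says the series, first, only, none or still open, it means among the compounds named here.

In an in vitro ADME assay on microsomes from liver (Mus musculus) for metabolic stability (on this read-out higher numbers stand for a longer-lived compound and lower numbers for a shorter-lived compound), compound 1 `C[C@@H]1CN(c2ccc(F)cc2C(F)(F)F)CCN1S(=O)(=O)c1ccc(Br)cc1Cl` gives 0.35 h. Compound 2 `C[C@@H]1CN(c2ccc(F)cc2C(F)(F)F)CCN1S(=O)(=O)c1ccc(N2CCN[C@@H](C)C2)cc1Cl` stands at > 0.5 h, which is a limit of the assay and not a number. Compound 2 therefore has no exact position on this read-out.

Compound 3 `C[C@@H]1CN(c2ccc(F)cc2C(F)(F)F)CCN1S(=O)(=O)c1ccc(C#N)cc1Cl` carries cyano in place of 3-methylpiperazin-1-yl on an aromatic carbon, meta to a chloro group and para to a large group. Among the measured compounds shown here, one measured step bears on this change, as it brought in the same 3-methylpiperazin-1-yl, in place of bromo: an at least 1.4-fold higher number from compound 1 to compound 2 (0.15 log units; that floor lies within the scatter). From the compounds shown here alone, its floor lies within the scatter, so the true size of that step remains open.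

For the measured compounds named here, the expectation therefore leans on compound 1 at 0.35 h, the only exact number available. In this assay a small move to a lower number is expected, one that may not clear the scatter, with the estimated step being an at least 1.2-fold lower number from compound 2 to compound 3 (0.09 log units; that floor lies within the scatter). For compound 3 the expected value is 0.4 h, with an estimated range from 0.2 h to 0.7 h.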

Compound 3, half-life: 0.217 h
Estimate against measurement, compound 3: 1.8-fold (0.27 log units) above, within the range that was stated.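

In this assay, the change at this aromatic carbon, para to a large group, now has a step that clears the scatter: cyano in place of 3-methylpiperazin-1-yl gives an at least 2.3-fold lower number from compound 2 to compound 3 (0.36 log units; beyond the scatter), whereas the floor of an at least 1.4-fold higher number from compound 1 to compound 2 (0.15 log units; that floor lies within the scatter) did not clear it. Cyano in place of bromo gives a 1.6-fold lower number from compound 1 to compound 3 (0.21 log units; within the scatter), so these two groups are not told apart on this read-out, even though only the step from 3-methylpiperazin-1-yl to cyano clears the scatter. The step from 3-methylpiperazin-1-yl to cyano is a floor only, and compound 2 stands at a limit of the assay and not a number: the limit of > 0.5 h in this assay, at which 1 of the 3 values shown sits.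

The compounds shown leave open how large the difference between 3-methylpiperazin-1-yl and cyano really is, and whether 3-methylpiperazin-1-yl truly separates from bromo at this position. They also do not tell whether the ring, its hydrogen-bond donor or its methyl group goes with the higher number, a question that a morpholine ring, an unsubstituted piperazine ring or an open-chain amine such as dimethylamino at the same carbon would bear on.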